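The source may report more compounds than this note shows. Statements on the series, on what has been measured and on what is new or still open speak of the compounds shown alone.

Series notes. Three compounds have numbers in a functional assay (Homo sapiens) for inhibition of Nucleic Acid, tested at 100 uM; on this read-out lower numbers stand for less inhibition and higher numbers for more inhibition at the one concentration tested (going by the name of the read-out). Compound 1 `CCNc1nccc2c1ncn2C1O[C@H](CO)[C@@H](O)[C@H]1O` gives 4% in this assay, the second highest of the three; compound 2 `CN(C)c1nccc2c1ncn2[C@H]1C[C@H](O)[C@@H](CO)O1` gives 0%, a number within the scatter of compound 1, and compound 3 `C[C@H]1OC(n2cnc3c(N)nccc32)[C@H](O)[C@@H]1O` gives 18%, a number beyond the scatter above compound 1.

Compound 4 `CNc1nccc2c1ncn2C1O[C@H](CO)[C@@H](O)[C@H]1O` is not yet measured. It differs from compound 1 in one place: hydrogen in place of methyl on a saturated chain carbon bound to a nitrogen on an aromatic ring. Among the measured compounds shown here, no step between measured compounds matches this change, so the size is expected from the spread of the three numbers only. The step from compound 1 to compound 4 in this assay is estimated as a number 4 percentage points higher from compound 1 to compound 4 (within the scatter), a change not expected to reach beyond the scatter. Compound 4 is expected to give 8% in this assay, with a range from 0% to 20%.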

Compound 4, a percentage reported as inhibition, at one concentration (the size of the read-out at that concentration, not a potency): 8%
Beside the measured number, compound 4's estimate shows no gap at the digits printed, within the range that was stated.
By their numbers in this assay, from the lowest: compounds 2, 1, 4 and 3 (each within the scatter of the next, the first and the last beyond it).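

Among the compounds shown here, the first one-place step, ethylamino to methylamino in this assay, reads a number 4 percentage points higher from compound 1 to compound 4 (within the scatter) and stays inside the usual scatter. For this pair, then, the methyl at this position can go without moving the read-out beyond that scatter. No supporting data bear on this result.

From the compounds shown here alone, whether a longer chain such as propyl or butyl in place of ethyl, or a chain ending in a carboxylic acid, would reach beyond the scatter remains open. Going by these compounds, whether the same step holds on the other compounds also remains open.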